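The source may hold more compounds than are shown below. What is called first, only, known or untested is meant among the compounds shown, and "the series" means these compounds.

For the measured compounds named here, in a physicochemical assay for lipophilicity, read by HPLC, measured as chromatographic lipophilicity, at pH 7.4 (on this read-out higher numbers stand for higher lipophilicity and lower numbers for lower lipophilicity), compound 1 (`COc1cccc(NC(=O)c2nnn(CC3CCN(C(C)=O)CC3)c2N)c1`) gives 1.2 and stands lowest of the two numbers so far, with compound 2 (`COc1cccc(NC(=O)c2nnn(Cc3ccc(C#N)cc3)c2N)c1`) at 2.3 above it. Going by the values given here, the one measured step runs a number 1.10 log units higher from compound 1 to compound 2 (beyond the scatter) and is large. That step puts 4-cyanophenyl in place of 1-acetylpiperidin-4-yl on a saturated chain carbon bound to an aromatic nitrogen, so it serves only as a rough guide to size. Compound 3 (`COc1cccc(NC(=O)c2nnn(CC3CCN(C(=O)OC(C)(C)C)CC3)c2N)c1`) carries tert-butoxy in place of methyl on a carbonyl carbon. Among the compounds with values here, no measured step changes that place. Taking a number 1.10 log units higher from compound 1 to compound 2 (beyond the scatter) as the only guide, a step of similar size is expected, upward and beyond the scatter. The estimate reads a number 1.20 log units higher from compound 1 to compound 3 (beyond the scatter) as the expected step. Compound 3 is expected at 2.4 with an estimated range from 2 to 2.9 in this read-out.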

Compound 3, distribution coefficient: 2.9
For compound 3 the middle estimate is 0.50 log units below the measured one, within the range that was stated.
By their numbers in this assay, from the lowest: compound 1; then compound 2; then compound 3.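

On a carbonyl carbon bound to an amide-type nitrogen in a ring, a change confined to this one place can move the number substantially: in this assay, tert-butoxy in place of methyl gives a number 1.70 log units higher from compound 1 to compound 3 (beyond the scatter). The earlier step replaced the whole 1-acetylpiperidin-4-yl group, whereas this one keeps the ring and goes from acetyl to tert-butoxycarbonyl, with tert-butoxy bringing 5 heavy atoms and 1 hydrogen-bond acceptor against the 1 heavy atom of methyl. Nothing available explains the size of this step.

With only methyl and tert-butoxy at this carbonyl carbon, the step cannot yet be assigned to the added carbons or to the added oxygen. An isopropyl or a methoxy group at the same place would separate the two.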